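Diethylamino to isopropylamino: a half-life outlook

The source may hold more compounds than are shown below. What is called first, only, known or untested is meant among the compounds shown, and "the series" means these compounds.

Of the compounds shown here, three have been measured in an ADME assay on microsomes from liver (Homo sapiens) for metabolic stability, read by LC-MS, using NADPH, with a stated time of 60 min, tested at 10 uM; a higher number here means that the compound lasts longer, a lower number that the compound disappears faster.
Compound 1 `O=C([C@@H]1CCCN(S(=O)(=O)c2ccc(S(=O)(=O)C3CCC3)cc2)C1)N1CCC(F)(F)CC1`: in this assay compound 1 sits at the assay limit > 1 h, which is a limit and not a number.
Compound 2 `CN(C)S(=O)(=O)c1ccc(S(=O)(=O)N2CCC[C@@H](C(=O)N3CCC(F)(F)CC3)C2)cc1`: in this assay compound 2 likewise sits at the limit > 1 h.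
Compound 3 `CCN(CC)S(=O)(=O)c1ccc(S(=O)(=O)N2CCC[C@@H](C(=O)N3CCC(F)(F)CC3)C2)cc1`: in this assay compound 3 gives 0.0457 h.

Among the compounds with values here, compound 3 therefore holds the only real number in the set; the other two values are limits, as the limit of > 1 h in this assay, at which 2 of the 3 values shown sit, states. Among the readable steps, there is an at least 21-fold lower number from compound 2 to compound 3 (1.34 log units; beyond the scatter), and there is an at least 21-fold lower number from compound 1 to compound 3 (1.34 log units; beyond the scatter), both far beyond the scatter and both pointing the same way: the diethylamino group on the sulfonyl sulfur goes with a much shorter half-life than the dimethylamino or cyclobutyl group. The remaining pair is unreadable, since a step that the two limits leave unreadable from compound 1 to compound 2.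

Compound 4 `CC(C)NS(=O)(=O)c1ccc(S(=O)(=O)N2CCC[C@@H](C(=O)N3CCC(F)(F)CC3)C2)cc1` differs from compound 3 in one place: isopropylamino in place of diethylamino on a sulfonyl sulfur. This change removes one carbon and introduces an amide-type hydrogen on the nitrogen, moving part of the way back toward the smaller groups of compounds 1 and 2. For compound 4 a rise in this assay is therefore expected, though its size is uncertain; the expected step is a 6.6-fold higher number from compound 3 to compound 4 (0.82 log units; beyond the scatter). Compound 4 is estimated at 0.3 h, within a range of 0.06 h to 1.2 h.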

Compound 4, half-life: 0.328 h
For compound 4 the middle estimate is 1.1-fold (0.04 log units) below the measured one, within the range that was stated.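

In this assay, the change of group on the sulfonyl sulfur does not act as a simple switch between a short and a long half-life, since isopropylamino gives an intermediate result, with a 7.2-fold higher number from compound 3 to compound 4 (0.86 log units; beyond the scatter). Within the data shown here, compound 4 still falls short of the two compounds with limit values, with an at least 3.0-fold lower number from compound 2 to compound 4 (0.48 log units; beyond the scatter) and with an at least 3.0-fold lower number from compound 1 to compound 4 (0.48 log units; beyond the scatter), so replacing diethylamino recovers only part of the gap seen in the earlier compounds. These last two steps give only a minimum size, and how far compound 4 really lies from either neighbour cannot be read: the limit of > 1 h in this assay, at which 2 of the 4 values shown sit.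

The step to isopropylamino changes the carbon count and the hydrogen-bond donor count together, and the two changes cannot be told apart from these compounds alone. A group such as ethylamino, which keeps the nitrogen hydrogen on a shorter chain, or methyl(isopropyl)amino, which has no such hydrogen, would be needed on the same sulfur to separate them.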